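A few compounds are considered here, and "the series" means these few. Any claim that something is new, unique, unknown or untested is made for them only; others in the source may bear on it.

The compounds share one core, shown in compound 1 `O=C(/C=C\Nc1ccc(C(F)(F)F)cc1)c1cn(-c2ccccc2)nc1-c1ccccc1`. In a functional assay on HT-29 cells (Homo sapiens) for antiproliferative activity, read by MTT assay, with a stated time of 48 h (on this read-out lower numbers stand for stronger inhibition and higher numbers for weaker inhibition), compound 1 gives > 50000 nM, which is a limit of the assay rather than a number. Compound 1 therefore stands at the weak end of the set, sitting at the limit of > 50000 nM in this assay, at which 1 of the 3 values shown sits. Its two measured neighbours differ from it only at the anilino ring: compound 2 `O=C(/C=C\Nc1ccc(O)cc1)c1cn(-c2ccccc2)nc1-c1ccccc1` carries a hydroxy in place of the trifluoromethyl and gives 5000 nM in this assay, and compound 3 `COc1ccc(N/C=C\C(=O)c2cn(-c3ccccc3)nc2-c2ccccc2)cc1` carries a methoxy there and gives 1560 nM in this assay. The steps of an at least 10-fold lower number from compound 1 to compound 2 (1.00 log units; beyond the scatter) and an at least 32-fold lower number from compound 1 to compound 3 (1.50 log units; beyond the scatter) are both beyond the scatter, and a 3.2-fold lower number from compound 2 to compound 3 (0.51 log units; beyond the scatter) separates the two.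

Compound 4 `O=C(/C=C\Nc1ccc(C(F)(F)F)cc1)c1cn(-c2ccccc2)nc1-c1ccc(Cl)cc1` keeps the trifluoromethyl of compound 1 and differs elsewhere: chloro in place of hydrogen on an aromatic carbon, para to a large group, so that the phenyl becomes a 4-chlorophenyl. Within the data shown here, none of the measured steps touches this ring; all three alter the anilino substituent. Among the measured compounds shown here, no measured step therefore bears on the change, and it is expected to leave compound 4 near the position of compound 1 in this assay a number no higher from compound 1 to compound 4 (the limit leaves the size open). Compound 4 is estimated at 50000 nM in this assay, with a range from 15000 nM to 150000 nM, and the result may again be only a limit.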

Compound 4, half-maximal inhibitory concentration: > 50000 nM
Compound 4 was reported as a limit; the forecaster's own chance of this, stated with the estimate: 70%; the middle value sits exactly at the limit.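

In this assay compound 4 gives > 50000 nM which is a limit of the assay and not a number. Compound 1 is also reported as a limit, so the step between compound 1 and compound 4 cannot be read: the limit of > 50000 nM in this assay, at which 2 of the 4 values shown sit. The compounds shown leave open what 4-chlorophenyl in place of phenyl does to the number in this assay.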